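The source may hold more compounds than are shown below. What is called first, only, known or untested is meant among the compounds shown, and "the series" means these compounds.

Of the compounds shown here, three with a shared core have been measured in an assay on membranes from CHO cells for displacement of a labelled ligand from adenosine receptor A1 (Homo sapiens), read by scintillation counting, with a stated time of 60 min, tested at 1 uM; on this read-out lower numbers stand for less inhibition and higher numbers for more inhibition at the one concentration tested (going by the name of the read-out). Compound 1 `CC1=C(C(=O)C2CC2)C(c2ccsc2)NC(=O)N1` gives 2%, and compound 2 `CCN(CC)C(=O)C1=C(C)NC(=O)NC1c1ccsc1` gives 11%; the only listed step between measured compounds, a number 9 percentage points higher from compound 1 to compound 2 (within the scatter), concerns diethylamino in place of cyclopropyl on a carbonyl carbon and stays within the scatter. Compound 3 `CC1=C(C(=O)OCC2CCC2)C(c2ccco2)NC(=O)N1` gives 42%, the highest of the three numbers, beyond the scatter above both compound 2 and compound 1.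

Compound 4 `CC1=C(C(=O)OCC2CCC2)C(c2ccsc2)NC(=O)N1` differs from compound 3 in one place: thiophen-3-yl in place of furan-2-yl on a saturated ring carbon. Going by the values given here, no measured step bears on this change, since the thiophen-3-yl compounds 1 and 2 differ from compound 3 in the carbonyl group as well, so their lower numbers cannot be read as the effect of the ring swap alone. The expectation for compound 4 therefore rests on compound 3 and carries wide uncertainty, with a step of a number 7 percentage points lower from compound 3 to compound 4 (within the scatter) expected. Compound 4 is estimated at 35%, between 10% and 60%.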

Compound 4, a percentage reported as inhibition, at one concentration (the size of the read-out at that concentration, not a potency): 48%
Beside the measured number, compound 4's estimate is 13 percentage points below it; low and high end bracket the measured number.
By their numbers in this assay, from the lowest: compounds 1 and 2 (each within the scatter of the next); then compounds 3 and 4 (each within the scatter of the next).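

Placing thiophen-3-yl instead of furan-2-yl on this saturated ring carbon, with the cyclobutylmethoxy carbonyl group unchanged, gives a number 6 percentage points higher from compound 3 to compound 4 (within the scatter) and so does not separate the two rings on this read-out. With thiophen-3-yl now held fixed, the carbonyl group can be judged alone: cyclobutylmethoxy in place of diethylamino gives a number 37 percentage points higher from compound 2 to compound 4 (beyond the scatter) and cyclobutylmethoxy in place of cyclopropyl gives a number 46 percentage points higher from compound 1 to compound 4 (beyond the scatter), which ties the earlier low numbers to the group on the carbonyl carbon and not to the thiophen-3-yl ring. No available evidence explains either the large steps or the small one. As far as these compounds go, whether the two rings also match when diethylamino or cyclopropyl sits on the carbonyl carbon remains open. So does the outcome for a phenyl ring on the saturated ring carbon, or for a longer chain or a carboxylic acid in place of cyclobutylmethoxy.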